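The source may report more compounds than this note shows. Statements on the series, on what has been measured and on what is new or still open speak of the compounds shown alone.

For the measured compounds named here, in a physicochemical assay for solubility, in phosphate buffer (a higher number here means a more soluble compound, a lower number a less soluble compound), compound 1 `CCCCCCc1ccc(NC(=O)C=C(C)C)cc1` gives 37000 nM and compound 2 `C#CC(=O)Nc1ccc(CCCCCC)cc1` gives 60000 nM, so compound 2 stands within the scatter of its only measured neighbour. Going by the values given here, the sole measured step, a 1.6-fold higher number from compound 1 to compound 2 (0.21 log units; within the scatter), replaces only the group on the carbonyl carbon. Compound 3 `CCCCCCc1ccc(C(=O)C2CO2)cc1` brings a different change, ((oxiran-2-yl)carbonyl in place of (ethynylcarbonyl)amino on an aromatic carbon), with (oxiran-2-yl)carbonyl in place of (ethynylcarbonyl)amino on an aromatic carbon. Among the compounds with values here, no measured step covers that exchange, and the one available step is small, so no shift beyond the scatter is expected in either direction. The expected change is a 1.3-fold lower number from compound 2 to compound 3 (0.12 log units; within the scatter). Compound 3 is estimated at 45000 nM, with an expected range of 15000 nM to 100000 nM.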

Compound 3, solubility: 204000 nM
Estimate against measurement, compound 3: 4.5-fold (0.66 log units) below, outside the stated range (above it).
By their numbers in this assay, from the lowest: compounds 1 and 2 (each within the scatter of the next); then compound 3.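

In this assay, (oxiran-2-yl)carbonyl in place of (ethynylcarbonyl)amino on this aromatic carbon gives a 3.4-fold higher number from compound 2 to compound 3 (0.53 log units; beyond the scatter), whereas the earlier change on the carbonyl carbon stayed within the scatter. This shows that an exchange of the whole group at this position can move the read-out beyond the scatter, with the hydrogen-bond donor of the leaving group gone and the three-membered ring added in a single change. Nothing measured accounts for the step. The compounds shown leave open whether the loss of the donor or the gain of the ring carries the step. On these data alone, how an amine or a carboxylic acid on this aromatic carbon would read also remains open.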